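A few compounds are considered here, and "the series" means these few. Any claim that something is new, unique, unknown or untested is made for them only; others in the source may bear on it.

Measured compounds:
compound 1 `Cc1nn(-c2ncnc3nc[nH]c23)c2c1C(OCc1ccc(Cl)cc1Cl)CC(=O)N2` gives 4 nM in a functional assay on HEK293 cells for agonist activity at G-protein coupled receptor 39 (Homo sapiens), read by scintillation proximity assay and inositol phosphate accumulation, with a stated time of 75 min, in the presence of a further agent that is not named here; a lower number here means that less compound is needed, a higher number that more compound is needed for the effect
compound 2 `C/C(=N\NC(=O)c1cc2ccccc2cc1O)c1ccc(N)cc1` gives 1100 nM in this assay

Compound 1 has the lowest number of the two measured compounds in this assay; the nearest is compound 2, whose value lies well beyond the scatter of repeated measurements, so the two are clearly separated. Compound 3 `Cc1nn(-c2ncnc3nc[nH]c23)c2c1C(OCc1ccccc1F)CC(=O)N2` has not yet been measured. It differs from compound 1 by one change: 2-fluorophenyl in place of 2,4-dichlorophenyl on a saturated chain carbon bound to an oxygen on a saturated carbon. Within the data shown here, no step between two measured compounds covers this kind of exchange, so the two measured values give no direct guide to its size. The step from compound 1 to compound 3 in this assay is expected to be a moderate increase in the number, a 6.3-fold higher number from compound 1 to compound 3 (0.80 log units; beyond the scatter), beyond the usual scatter but far short of the gap to compound 2. Compound 3 is estimated to give 25 nM in this assay, within a range of 6 nM to 120 nM.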

Compound 3, half-maximal effective concentration: 4 nM
Compound 3: middle estimate off by 6.3-fold (0.80 log units), on the high side; measured number outside the range, below it.
By their numbers in this assay, from the lowest: compounds 1 and 3 (each within the scatter of the next); then compound 2.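

In this assay, putting 2-fluorophenyl in place of 2,4-dichlorophenyl on a saturated chain carbon bound to an oxygen on a saturated carbon gives no change at the digits printed from compound 1 to compound 3 (within the scatter). This shows what the earlier pair could not: at this place, the two chlorine atoms are not required to keep the number low, and an aromatic ring of carbon bearing a single fluorine serves as well within the scatter. No measurement at hand explains why the two groups read alike.

The compounds shown leave open whether an aromatic ring is needed here at all, since they give no reading for an unsubstituted phenyl, a cyclohexyl group or a longer chain at this place. Also open, as far as these compounds go, is whether the same exchange would read alike on a core other than that of compound 1.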